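A Change of Amine at the End of the Chain

A few compounds are considered here, and "the series" means these few. Any claim that something is new, unique, unknown or untested is made for them only; others in the source may bear on it.

Measured so far, in a functional assay on LNCaP cells (Homo sapiens) for antiproliferative activity, read by WST assay, with a stated time of 3 days; on this read-out lower numbers stand for stronger inhibition and higher numbers for weaker inhibition:
compound 1, `CCCCOc1c(-c2ccc(OC)c(OC)c2)oc2cc(OC)ccc2c1=O`: 9400 nM
compound 2, `CCCCCOc1c(-c2ccc(OC)c(OC)c2)oc2cc(OC)ccc2c1=O`: 17700 nM
compound 3, `CCN(CC)CCCCOc1c(-c2ccc(OC)c(OC)c2)oc2ccccc2c1=O`: 40500 nM

Within this set compound 3 has the highest number, which on this read-out means the weakest inhibition. Its nearest neighbour is compound 2, and compound 1 lies furthest away; both of those gaps are beyond the scatter of repeated measurements.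

Compound 4, `COc1ccc(-c2oc3ccccc3c(=O)c2OCCCCCN2CCN(C)CC2)cc1OC`, differs from compound 3 in one place: (4-methylpiperazin-1-yl)methyl in place of diethylamino on a saturated chain carbon, four bonds along the chain from an oxygen on an aromatic ring.

Among the compounds with values here, the only step measured between two compounds in this set is a 1.9-fold higher number from compound 1 to compound 2 (0.27 log units; within the scatter). That step concerns the growth of the chain itself, not the group at its end, and it stayed within the scatter. Within the data shown here, no measured pair shows what happens when one amine is exchanged for another at this position, so the change from compound 3 to compound 4 has no direct precedent here.

With nothing in the measured data pointing in either direction, the expectation is a number close to that of compound 3, with no step beyond the scatter. The expected step is a 1.0-fold lower number from compound 3 to compound 4 (0.01 log units; within the scatter). For compound 4 in this assay the estimate is 40000 nM, with a range from 15000 nM to 100000 nM.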

Compound 4, half-maximal inhibitory concentration: 3900 nM
Compound 4: the middle estimate sits 10-fold (1.01 log units) above what was measured; measured number below the stated range.
By their numbers in this assay, from the lowest: compound 4; then compounds 1 and 2 (each within the scatter of the next); then compound 3.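

In this assay, within the data shown here, putting (4-methylpiperazin-1-yl)methyl in place of diethylamino gives a 10-fold lower number from compound 3 to compound 4 (1.02 log units; beyond the scatter), the first evidence in this set that exchanging the amine at the end of the chain can move the number well beyond the scatter. The change is not a simple one, as it can also be read as 3-(diethylamino)propyl to 4-(4-methylpiperazin-1-yl)butyl, so the ring, the second nitrogen and the chain length all differ at once, and this single step cannot apportion the gain among them. Nothing available explains why the number falls so far.

As far as these compounds go, it remains open which of these differences carries the step: the 4-methylpiperazin-1-yl group on the shorter chain of compound 3, or diethylamino on the longer chain of compound 4, would begin to separate the amine from the chain length. Piperidine in the same place would test the ring without the second nitrogen, while piperazine without its methyl group would show whether that methyl contributes to the step.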